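The source may report more compounds than this note shows. Statements on the series, on what has been measured and on what is new or still open speak of the compounds shown alone.

Working notes on a three-compound set read in a functional assay on Hs-578T cells (Homo sapiens) for antiproliferative activity; on this read-out lower numbers stand for stronger inhibition of growth and higher numbers for weaker inhibition of growth. In this assay compound 1 `COc1cc(-n2cc(-c3ccc(Cl)cc3)[nH]c2=O)cc(OC)c1OC` gives 79400 nM, and compound 3 `COc1ccc(-n2cc(-c3ccc(OC)c(OC)c3)[nH]c2=S)cc1Cl` gives 39800 nM. These two numbers lie within the scatter of each other, so compound 1 cannot be separated from compound 3. Compound 2 `COc1cc(-c2cn(-c3ccc(Cl)cc3)c(=O)[nH]2)cc(OC)c1OC` reads > 100000 nM, which is a limit of the assay and not a number.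

Compound 4 `COc1cc(-n2cc(-c3ccccc3)[nH]c2=O)cc(OC)c1OC` has not yet been measured. It differs from compound 1 by hydrogen in place of chloro on an aromatic carbon, para to a large group, so that 4-chlorophenyl becomes phenyl. For the measured compounds named here, no measured pair in this set shows the same change, so the expectation starts from compound 1 at 79400 nM. No step beyond the scatter is expected, and neither direction is favoured. The estimated 1.0-fold higher number from compound 1 to compound 4 (0.00 log units; within the scatter) therefore stays small. For compound 4 the expected value is 80000 nM, with an estimated range of 30000 nM to 100000 nM.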

Compound 4, concentration for 50% growth inhibition: 31600 nM
Compound 4: middle estimate off by 2.5-fold (0.40 log units), on the high side, within the range that was stated.
By their numbers in this assay, from the lowest: compounds 4, 3 and 1 (each within the scatter of the next, the first and the last beyond it). At a limit, above all of these: compound 2.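

In this assay, for the compounds shown here, hydrogen in place of chloro gives a 2.5-fold lower number from compound 1 to compound 4 (0.40 log units; beyond the scatter), the first step that can be read in one place. The chloro para to a large group is therefore not required for the activity of compound 1, and the phenyl compound reads modestly better than the 4-chlorophenyl compound. This rests on a single pair on one core, and the step is modest.

Going by these compounds, whether an amine, a carboxylic acid or a methoxy group at this place would move the number further, and in which direction, stays open. Compound 2 also carries 4-chlorophenyl, but its reading of > 100000 nM is a limit and not a number, so whether the change holds on that arrangement cannot be read: the limit of > 100000 nM in this assay, at which 1 of the 4 values shown sits.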